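A few compounds are considered here, and "the series" means these few. Any claim that something is new, unique, unknown or untested is made for them only; others in the source may bear on it.

Compound 1 `CCCCCCCCN(C)C(=O)Cn1cc(Cc2cnc(=O)n(CC)c2)c(=O)nc1SCc1ccc(F)cc1` stands lowest of the three numbers available in a functional assay on a cell-free system (plasma) for inhibition of platelet-activating factor acetylhydrolase (Homo sapiens), tested at 100 nM; on this read-out lower numbers stand for less inhibition and higher numbers for more inhibition at the one concentration tested (going by the name of the read-out): compound 1 gives 48%. Compound 3 `CCCCCCCCCCCCN(C)C(=O)Cn1cc(Cc2cnc(=O)n(CC(=O)OCC)c2)c(=O)nc1SCc1ccc(F)cc1` lies nearest, with compound 3 giving 55%, a gap within the scatter. Compound 2 `CCCCCCCCCCCCN(C)C(=O)Cn1cc(Cc2cnc(=O)n(C)c2)c(=O)nc1SCc1ccc(F)cc1` lies furthest, with compound 2 giving 75%, beyond the scatter. Compound 2 and compound 1 differ in more than one place, so their two values are noted only as they stand. Compound 4 `CCCCCCCCN(C)C(=O)Cn1cc(Cc2cnc(=O)n(CC(=O)N3CCOCC3)c2)c(=O)nc1SCc1ccc(F)cc1` is not yet measured. It differs from compound 1 by (morpholin-4-yl)carbonyl in place of methyl on a saturated chain carbon bound to an aromatic nitrogen. Among the compounds with values here, the one measured step touching the same place is a number 20 percentage points lower from compound 2 to compound 3 (beyond the scatter), where a carbonyl-bearing group entered on the saturated chain carbon bound to the aromatic nitrogen. The (morpholin-4-yl)carbonyl entering in compound 4 is again a carbonyl-bearing group at that place, so a modest drop in this assay is expected, though compound 1 leaves less room downward because it already stands at 48%. The estimate for compound 4 is 38%, within 22% to 54%. For compound 4 the expected step is a number 10 percentage points lower from compound 1 to compound 4 (within the scatter), which may still overlap the scatter.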

Compound 4, a percentage reported as inhibition, at one concentration (the size of the read-out at that concentration, not a potency): 64%
Compound 4: the middle estimate sits 26 percentage points below what was measured; measured number outside the range, above it.
By their numbers in this assay, from the lowest: compounds 1, 3 and 4 (each within the scatter of the next, the first and the last beyond it); then compound 2.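

In this assay, the place on a saturated chain carbon bound to an aromatic nitrogen takes (morpholin-4-yl)carbonyl in place of methyl with a gain: a number 16 percentage points higher from compound 1 to compound 4 (beyond the scatter). Set beside a number 20 percentage points lower from compound 2 to compound 3 (beyond the scatter), this shows that a carbonyl-bearing group at this place does not move the number in one fixed direction, although the two steps start from different compounds and bring different groups. No measurement at hand bears on why the number rises here.

Open, from the compounds shown here alone, is whether the morpholine ring itself matters, or whether a piperidine amide, a dimethylamide or a carboxylic acid on the same carbon would serve alike. Also open, going by these compounds, is how (morpholin-4-yl)carbonyl behaves with the longer chain carried by compound 2 and compound 3.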